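The source may hold more compounds than are shown below. What is called first, only, known or untested is meant among the compounds shown, and "the series" means these compounds.

Measured compounds in the series:

compound 1, `COC(=O)c1cc(CC(C)CN2C[C@H]3CCCC[C@H]3[C@@H](C(=O)N3CCN(c4ccc([N+](=O)[O-])cc4)CC3)C2)cc(C(=O)OC)c1` — 107 nM
compound 2, `COC(=O)c1cc(CC(C)CN2C[C@@H]3CCCC[C@@H]3[C@H](C(=O)N3CCN(c4ccc([N+](=O)[O-])cc4)CC3)C2)cc(C(=O)OC)c1` — 1.35 nM
compound 3, `Cc1nc2cc(C[C@H](C)CN3C[C@@H]4CCCC[C@@H]4[C@H](C(=O)N4CCN(c5ccc(F)c(F)c5)CC4)C3)ccc2o1` — 3.39 nM

In an assay on isolated protein for binding affinity to somatostatin receptor type 3 (Homo sapiens) (a higher number here means weaker binding, a lower number tighter binding), compound 3 stands second highest of the three numbers: compound 2 gives a lower number than compound 3, beyond the scatter, and compound 1 gives a higher number than compound 3, also beyond the scatter. Among the measured compounds shown here, the only step measured so far is a 79-fold lower number from compound 1 to compound 2 (1.90 log units; beyond the scatter), a change of ring stereochemistry alone, which the fact that one of compounds 1 and 2 is drawn with a defined configuration and the other without, at the place where they differ ties to the drawn configuration of the shared core rather than to any substituent.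

Compound 4, `C[C@@H](Cc1ccc2ncnn2c1)CN1C[C@@H]2CCCC[C@@H]2[C@H](C(=O)N2CCN(c3ccc(F)c(F)c3)CC2)C1`, differs from compound 3 by a group of 9 heavy atoms (6 carbon, 3 nitrogen; one five-membered aromatic ring with 3 hetero atoms, one six-membered aromatic ring with 1 hetero atom) in place of a group of 10 heavy atoms (8 carbon, 1 nitrogen, 1 oxygen; one five-membered aromatic ring with 2 hetero atoms, one six-membered aromatic ring of carbon only), on a saturated chain carbon, three bonds along the chain from an amine nitrogen in a ring. For the measured compounds named here, no measured step touches this part of the molecule, so the stereochemical step from compound 1 to compound 2 gives no direct guide to the size or direction of the change expected in this assay; with both compounds on the core configuration of compound 2 and compound 3, the working expectation is a step not beyond the scatter. Compound 4 is therefore estimated at 4 nM (range 1.3 nM to 12 nM), an expected step of a 1.2-fold higher number from compound 3 to compound 4 (0.07 log units; within the scatter).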

Compound 4, dissociation constant: 34.7 nM
The estimate for compound 4 lay 8.7-fold (0.94 log units) below the measured number; the measured number lies above the stated range.
By their numbers in this assay, from the lowest: compound 2; then compound 3; then compound 4; then compound 1.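

In this assay, replacing 2-methyl-1,3-benzoxazol-5-yl with the group bearing a five-membered aromatic ring with 3 hetero atoms and a six-membered aromatic ring with 1 hetero atom gives a 10-fold higher number from compound 3 to compound 4 (1.01 log units; beyond the scatter). Among the compounds shown here, this is the first measured step at this place, on a saturated chain carbon, three bonds along the chain from an amine nitrogen in a ring, and it shows that the affinity depends on the fused aromatic group held there, even with the shared core unchanged. Nothing measured here accounts for the size or direction of this step.

A single pair cannot show which part of the exchange carries the step, whether the methyl group, the ring oxygen or the ring nitrogens. It also leaves open how a plain phenyl, a pyridine or a benzoxazole without the methyl group would stand at this place.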